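A Methoxy in Place of a Methyl

A few compounds are considered here, and "the series" means these few. Any claim that something is new, unique, unknown or untested is made for them only; others in the source may bear on it.

Measured so far:
compound 1 `Cc1ccc(-c2nn(-c3ccc(Cl)cc3)cc2-c2cc(-c3ccc(Cl)cc3)[nH]c2-c2ccc(F)cc2)cc1`: 21%
compound 2 `COc1ccc(-c2[nH]c(-c3ccc(Cl)cc3)cc2-c2cn(-c3ccc(Cl)cc3)nc2-c2ccc(C)cc2)cc1`: 21.3%

In a functional assay on the whole organism (strain Wistar albino) for inhibition, with Rattus norvegicus as the target, read by paw edema, with stated times of 1 h and 3 h, at a dose of 0.32 mmol/kg by the intraperitoneal route (a lower number here means less inhibition, a higher number more inhibition at the dose given (going by the name of the read-out)), compound 1 gives 21%, the lower of the two numbers, while compound 2 gives 21.3%. For the measured compounds named here, the only step seen, a number 0.3 percentage points higher from compound 1 to compound 2 (within the scatter), came from methoxy in place of fluoro on an aromatic carbon and stayed within the scatter. Compound 3 `COc1ccc(-c2nn(-c3ccc(Cl)cc3)cc2-c2cc(-c3ccc(Cl)cc3)[nH]c2-c2ccc(F)cc2)cc1` differs from compound 1 by methoxy in place of methyl on an aromatic carbon. Going by the values given here, that earlier step is the only guide, so no change beyond the scatter is expected, no change at the digits printed from compound 1 to compound 3 (within the scatter). Compound 3 is therefore estimated at 21%, with a range from 12% to 31%.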

Compound 3, a percentage reported as inhibition, in the whole organism at one dose (the size of the read-out at that dose, not a potency): 61.9%
Beside the measured number, compound 3's estimate is 40.9 percentage points below it, outside the stated range (above it).
By their numbers in this assay, from the lowest: compounds 1 and 2 (each within the scatter of the next); then compound 3.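

In this assay, changing 4-methylphenyl to 4-methoxyphenyl gives a number 40.9 percentage points higher from compound 1 to compound 3 (beyond the scatter), so this position on the core of compound 1 responds strongly to a single small change. The earlier step, a number 0.3 percentage points higher from compound 1 to compound 2 (within the scatter), put a methoxy at a different aromatic place, which shows that the same group does not have the same effect everywhere on this core. Nothing measured here accounts for the gain.

The compounds shown leave open whether a hydroxy, an amine or a longer chain such as ethoxy at this same place would keep the gain.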